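This account rests on a few compounds, and the source may have more. Where it says the series, first, only, none or still open, it means among the compounds named here.

Compounds measured in an ADME assay on S9 fraction from liver (Rattus norvegicus) for metabolic stability, read by LC-MS, using NADPH, with a stated time of 30 min; a lower number here means that less of the compound is left, a higher number that more of the compound is left:
- compound 1 `CCCCCCCCc1ccc(OCC(=O)Cn2nnc(C)n2)cc1`: < 5%
- compound 2 `CCCCCCCCc1ccc(OCC(=O)Cn2nnc(C(=O)O)n2)cc1`: 52%
- compound 3 `CCCCCCCCc1ccc(OCC(=O)Cn2nnnc2SC)cc1`: 21%

The entry for compound 1 is a limit of the assay and not a number. Of the two actual numbers, compound 3 holds the lower, at 21%.

Compound 4 `CCCCCCCCc1ccc(OCC(=O)Cn2nnnc2-c2ccc(S(=O)(=O)N(C)C)cc2)cc1` is the next to be tested in this assay. It carries 4-(dimethylsulfamoyl)phenyl in place of methylsulfanyl on an aromatic carbon.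

For the measured compounds named here, three measured steps bear on this change, all in the same part of the molecule. The first is large, a number at least 47 percentage points higher from compound 1 to compound 2 (beyond the scatter). The second is at least modest, a number at least 16 percentage points higher from compound 1 to compound 3 (beyond the scatter). The third is again large, a number 31 percentage points lower from compound 2 to compound 3 (beyond the scatter). This part of the molecule can therefore move the read-out considerably, but none of these steps brings in a group with an aromatic ring, so they set no clear direction. No shift beyond the scatter is therefore expected, though with wide uncertainty: the expected step is a number 4 percentage points higher from compound 3 to compound 4 (within the scatter). For compound 4 the estimated value is 25%, within an expected range from 6% to 55%.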

Compound 4, percent of the compound remaining: 40%
Compound 4: middle estimate off by 15 percentage points, on the low side; the measured number falls inside the stated range.
By their numbers in this assay, from the lowest: compound 3; then compound 4; then compound 2. At a limit, below all of these: compound 1.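

At this position, on an aromatic carbon of a five-membered aromatic ring with 4 nitrogen, the change to 4-(dimethylsulfamoyl)phenyl gives in this assay a number 19 percentage points higher from compound 3 to compound 4 (beyond the scatter). This is the first step shown in which the entering group brings a six-membered aromatic ring, and it shows that such a much larger group can go onto this carbon with more of the compound left, not less. Compound 1 stands only as a limit, so the steps from it have no exact size: the limit of < 5% in this assay, at which 1 of the 4 values shown sits.

The compounds shown leave open whether the phenyl ring alone or the dimethylsulfamoyl group on it accounts for this step. An unsubstituted phenyl, or a phenyl bearing an amine or a carboxylic acid instead, would separate the two.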